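Methylsulfanyl for hydrogen on the benzyl ring of compound 2

This account rests on a few compounds, and the source may have more. Where it says the series, first, only, none or still open, it means among the compounds named here.

Compound 1, `CSc1nc(NCc2ccc([Se]C)cc2)c2ccccc2n1`: > 100000 nM in an ADME assay on BEAS-2B cells (Homo sapiens) for cytotoxicity, read by MTT assay, with a stated time of 72 h; a higher number here means a weaker inhibitor of growth, a lower number a stronger inhibitor of growth
Compound 2, `CSc1nc(NCc2ccccc2)c2ccccc2n1`: 88200 nM

In this assay compound 1 gives > 100000 nM, which is a limit of the assay and not a number. Compound 2 gives 88200 nM in this assay; it is the only number shown. Compound 3, `CSc1ccc(CNc2nc(SC)nc3ccccc23)cc1`, is not yet measured in this assay and differs from compound 2 by methylsulfanyl in place of hydrogen on an aromatic carbon. Among the measured compounds shown here, the one measured step that bears on this is an at least 1.1-fold lower number from compound 1 to compound 2 (0.05 log units; that floor lies within the scatter), where a group of the same kind sat at the same place and its removal changed little. Putting methylsulfanyl back in that place is therefore expected to move compound 3 toward (the limit of > 100000 nM in this assay, at which 1 of the 2 values shown sits), with the expected step being a 1.1-fold higher number from compound 2 to compound 3 (0.05 log units; within the scatter). Compound 3 is estimated at 100000 nM, with a range from 60000 nM to 200000 nM, and a limit rather than a number is a likely outcome.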

Compound 3, concentration for total growth inhibition: 59100 nM
Beside the measured number, compound 3's estimate is 1.7-fold (0.23 log units) above it; the measured number lies below the stated range.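

In this assay, methylsulfanyl in place of hydrogen on this aromatic carbon, para to a large group, gives a 1.5-fold lower number from compound 2 to compound 3 (0.17 log units; within the scatter), so compound 2 and compound 3 read alike and the position takes this sulfur group with a measured number rather than a limit. From the compounds shown here alone, exchanging the selenium group for the sulfur group at the same place gives an at least 1.6-fold lower number from compound 1 to compound 3 (0.22 log units; that floor lies within the scatter), which is only a floor, so the true size of that step stays unknown. Compound 1 alone stands at a limit, which is not a number: the limit of > 100000 nM in this assay, at which 1 of the 3 values shown sits.

Whether any group at this position can move the number beyond the scatter remains open, since only hydrogen, methylsulfanyl and the selenium group are shown there. An amine, a carboxylic acid or a longer chain on the same carbon would test this.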